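The source may report more compounds than this note shows. Statements on the series, on what has been measured and on what is new or still open speak of the compounds shown alone.

Working notes on the series. Compound 1 (`COc1cc(CCCCC(C)(C)O)oc(=O)c1C`) reads > 200000 nM in a functional assay on HCT-116 cells (Homo sapiens) for cytotoxicity, read by MTT assay (on this read-out lower numbers stand for stronger inhibition and higher numbers for weaker inhibition), and this is a limit, not a number. Compound 2 (`CC(=O)C(C)CCCCc1cc(O)c(C)c(=O)o1`) reads > 200000 nM and this is likewise a limit. Compound 3 (`Cc1c(O)cc(CCCC(C)C)oc1=O`) reads > 200000 nM and this too is only a limit, so compound 3 has no number to start from. Within the data shown here, all values so far stand at one limit (the limit of > 200000 nM in this assay, at which 3 of the 3 values shown sit).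

Compound 4 (`Cc1c(O)cc(CCCCC(C)(C)O)oc1=O`) follows from compound 3 by one change (2-hydroxy-2-methylpropyl in place of isopropyl on a saturated chain carbon, three bonds along the chain from an aromatic carbon): 2-hydroxy-2-methylpropyl in place of isopropyl on a saturated chain carbon, three bonds along the chain from an aromatic carbon. Among the measured compounds shown here, the only measured step that bears on this place (a step that the two limits leave unreadable from compound 2 to compound 3) has no readable size. In this assay no step beyond the scatter is therefore expected, and no direction can be given. The expected step (a number no higher from compound 3 to compound 4 (the limit leaves the size open)) is accordingly an estimate of no real change. For compound 4 the estimate is 200000 nM with an expected range from 80000 nM to 400000 nM and a limit instead of a number is the likely report.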

Compound 4, half-maximal inhibitory concentration: > 200000 nM
Compound 4: only a limit was reported; the forecaster's own chance of this, stated with the estimate: 80%; the middle value sits exactly at the limit.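

Compound 4 gives only a limit, so its steps from compound 1, compound 2 and compound 3 cannot be read: the limit of > 200000 nM in this assay, at which 4 of the 4 values shown sit.

The compounds shown leave open whether any change to the shared core or its chain would give a number rather than a limit in this assay.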